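The source may report more compounds than this note shows. Statements on the series, on what has been measured and on what is new or still open speak of the compounds shown alone.

Compound 1 `Cc1cn([C@H]2C[C@H](CC3=CC(=O)C(=O)C=C3)[C@@H](CO[Si](C)(C)C(C)(C)C)O2)c(=O)[nH]c1=O`: no result reported
Compound 2 `COc1ccc(C2([C@H]3C[C@H](n4cc(C)c(=O)[nH]c4=O)O[C@@H]3CO[Si](C)(C)C(C)(C)C)SCCCS2)cc1OC`: 4470 nM

In a functional assay on St-4 cells (Homo sapiens) for inhibition, read by sulforhodamine B assay, with a stated time of 48 h (on this read-out higher numbers stand for weaker inhibition of growth and lower numbers for stronger inhibition of growth), compound 2 gives 4470 nM. For the measured compounds named here, this is the only number available, so compound 2 cannot yet be ranked against another compound. Compound 3 `COc1ccc(C2([C@H]3C[C@@H](n4cc(C)c(=O)[nH]c4=O)O[C@@H]3CO[Si](C)(C)C(C)(C)C)SCCCS2)cc1OC` is a close relative of compound 2: the two compounds have the same atoms and bonds and differ only in configuration as drawn: 1 of 3 stereo elements differ; a stereocentre at a saturated ring carbon is drawn R in compound 2 and S in compound 3. Going by the values given here, no measured pair shows what such a change does in this assay. The expected 1.2-fold higher number from compound 2 to compound 3 (0.09 log units; within the scatter) is therefore no larger than the usual scatter, and its direction is uncertain. For compound 3 the estimated value is 5500 nM, with an expected range from 2000 nM to 15000 nM.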

Compound 3, concentration for 50% growth inhibition: 12000 nM
Compound 3: the middle estimate sits 2.2-fold (0.34 log units) below what was measured; measured number inside the range.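

In this assay, changing one saturated ring carbon from R to S gives a 2.7-fold higher number from compound 2 to compound 3 (0.43 log units; beyond the scatter), so the R form, compound 2, inhibits growth more strongly. For the compounds shown here, this is the first measured pair to show that configuration at this stereocentre can shift the result beyond the scatter. The shift can be assigned to this centre alone because nothing else changes: the fact that compounds 2 and 3 differ only in the configuration as drawn

This modest step rests on a single pair. Going by these compounds, whether the R form would still be favoured with a free hydroxyl group or an amine on the shared core remains open.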